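This account rests on a few compounds, and the source may have more. Where it says the series, first, only, none or still open, it means among the compounds named here.

Compound 3, whose structure is `Nc1scc(CN2CCN(c3ccc(F)c(F)c3)CC2)c1C(=O)c1ccc(Cl)cc1`, is one of three close relatives that share a core and differ only in the aromatic group attached to an amine nitrogen in a ring. In a functional assay on CHO cells with adenosine receptor A1 (Homo sapiens) as the target, read by cAMP accumulation and immunoassay, with a stated time of 6 min, tested at 10 uM (on this read-out lower numbers stand for a stronger effect and higher numbers for a weaker effect at the one concentration tested), compound 3 gives -87%, the lowest of the three numbers. Compound 1, with structure `Nc1scc(CN2CCN(c3ccc(Cl)cc3Cl)CC2)c1C(=O)c1ccc(Cl)cc1`, gives -74%, and compound 2, with structure `Nc1scc(CN2CCN(c3ccccc3F)CC2)c1C(=O)c1ccc(Cl)cc1`, gives -15%. The steps between them are a number 13 percentage points lower from compound 1 to compound 3 (beyond the scatter), a number 72 percentage points lower from compound 2 to compound 3 (beyond the scatter) and a number 59 percentage points higher from compound 1 to compound 2 (beyond the scatter).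

Compound 4, with structure `Nc1scc(CN2CCN(c3c(F)cc(F)cc3F)CC2)c1C(=O)c1ccc(Cl)cc1`, has not yet been measured. It differs from compound 3 in one place: 2,4,6-trifluorophenyl in place of 3,4-difluorophenyl on an amine nitrogen in a ring. All three measured steps bear on this change, since each swaps the same aromatic group on the same ring nitrogen, and they range from modest to large. Compound 2 shows that a lone fluorine on that ring weakens the effect strongly, while compound 1 shows two halogens keeping it strong, so a swing in either direction is possible. The step is expected to be a number 32 percentage points higher from compound 3 to compound 4 (beyond the scatter). Compound 4 is therefore expected to give -55%, within a range from -90% to -10%.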

Compound 4, a percentage reported as activity, at one concentration (the size of the read-out at that concentration, not a potency): -78%
The estimate for compound 4 lay 23 percentage points above the measured number; measured number inside the range.
By their numbers in this assay, from the lowest: compounds 3, 4 and 1 (each within the scatter of the next, the first and the last beyond it); then compound 2.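

In this assay, the change at this ring nitrogen gives a number 9 percentage points higher from compound 3 to compound 4 (within the scatter), and replacing the group of compound 1 gives a number 4 percentage points lower from compound 1 to compound 4 (within the scatter), so compound 4 cannot be told apart from either compound. The step from the lone-fluorine compound, a number 63 percentage points lower from compound 2 to compound 4 (beyond the scatter), adds a new point: the name 2,4,6-trifluorophenyl includes the 2-fluoro of 2-fluorophenyl, so having that fluorine does not by itself bring the weak number of compound 2. No measurement at hand explains why these aromatic groups differ in this way.

The compounds shown leave open how this read-out would respond to a plain phenyl group with no halogen on this nitrogen. They also leave open the effect of a methoxy group on that aromatic ring.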